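The source may hold more compounds than are shown below. What is called first, only, known or untested is meant among the compounds shown, and "the series" means these compounds.

Three compounds share one core, a sulfonamide joined to a pair of linked saturated rings, and differ only in the group on the far end of the aromatic ring. Compound 1 `CC1CCN(C2CCN(S(=O)(=O)c3ccc(-c4ccccc4)cc3)CC2)CC1` carries a plain phenyl there and in a functional assay on DLD-1 cells (Homo sapiens) for antiproliferative activity, read by CellTiter-Glo, with a stated time of 72 h (a lower number here means a stronger inhibitor, a higher number a weaker inhibitor), compound 1 gives 258 nM. Compound 2 `CC1CCN(C2CCN(S(=O)(=O)c3ccc(-c4ccc(Cl)cc4)cc3)CC2)CC1` adds a chloro to that phenyl, and in this assay compound 2 gives 105 nM, a change of a 2.5-fold lower number from compound 1 to compound 2 (0.39 log units; beyond the scatter). Compound 3 `CCc1ccc(S(=O)(=O)N2CCC(N3CCC(C)CC3)CC2)cc1` has only an ethyl in that place. For compound 3 this assay reports no number but a limit, > 5000 nM, the point described by the limit of > 5000 nM in this assay, at which 1 of the 3 values shown sits. Compound 3 therefore stands at the weak end of what has been measured, with a loss of an at least 19-fold higher number from compound 1 to compound 3 (1.28 log units; beyond the scatter) and of an at least 47-fold higher number from compound 2 to compound 3 (1.67 log units; beyond the scatter).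

Compound 4 `CCCCOc1ccc(S(=O)(=O)N2CCC(N3CCC(C)CC3)CC2)cc1` is not yet measured. It keeps the core of compound 3 but puts a butoxy in place of ethyl on an aromatic carbon. Both measured steps into compound 3 show that replacing an aromatic group at this place with a short chain costs a great deal, and a longer chain with an oxygen is still a chain rather than a ring. The expected step is therefore a number no higher from compound 3 to compound 4 (the limit leaves the size open), meaning little change beyond the scatter. Compound 4 is estimated at 5000 nM, between 1500 nM and 20000 nM.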

Compound 4, half-maximal inhibitory concentration: 2300 nM
Compound 4: middle estimate off by 2.2-fold (0.34 log units), on the high side; the measured number falls inside the stated range.
By their numbers in this assay, from the lowest: compound 2; then compound 1; then compound 4. At a limit, above all of these: compound 3.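

In this assay, the butoxy chain gives compound 4 a measured number where the ethyl of compound 3 gave only a limit, so a chain at this place can keep some activity, with an at least 2.1-fold lower number from compound 3 to compound 4 (0.33 log units; beyond the scatter). Compound 3 has a limit rather than a number, so this step gives only a smallest size: the limit of > 5000 nM in this assay, at which 1 of the 4 values shown sits. Even so, butoxy does not match the aromatic groups, with an 8.9-fold higher number from compound 1 to compound 4 (0.95 log units; beyond the scatter) and a 22-fold higher number from compound 2 to compound 4 (1.34 log units; beyond the scatter), so among these four compounds the two carrying a second aromatic ring both stay ahead of the two carrying a chain.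

Butoxy differs from ethyl both in length and in carrying an oxygen, and the compounds shown do not separate the two, which a plain butyl chain or a short methoxy could do. Also open, on these data alone, is how an amine or a carboxylic acid at the end of such a chain, or a pyridine ring in place of the phenyl of compound 1, would behave in this assay.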